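Glycine transporter 1 series: ring substitution on the benzamide

The compounds below may be only part of what the source reports. "The series", "measured", "known", "first", "only" and "open" are said of these compounds alone.

Compound 2 `CN1CCCC(NC(=O)c2ccc(C(F)(F)F)cc2)(c2ccccc2)C1` carries an aromatic amide on the shared core bearing a single trifluoromethyl group. In an assay on cells for inhibition of sodium- and chloride-dependent glycine transporter 1 (Homo sapiens) (on this read-out higher numbers stand for an effect only at larger amounts of compound and lower numbers for an effect already at smaller amounts), compound 2 gives a result that is a limit of the assay, > 10000 nM. Compound 1 `COc1cc(C(F)(F)F)cc(C(F)(F)F)c1C(=O)NC1(c2ccccc2)CCCN(C(C)=O)C1`, a related amide with a methoxy group and two trifluoromethyl groups on the aromatic ring, likewise gives only a limit in this assay, > 10000 nM. Compound 2 therefore stands at the limit together with the other value shown, as recorded in the limit of > 10000 nM in this assay, at which 2 of the 2 values shown sit; neither value ranks above the other.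

Compound 3 `CSc1cc(C(F)(F)F)ccc1C(=O)NC1(c2ccccc2)CCCN(C)C1` differs from compound 2 by methylsulfanyl in place of hydrogen on an aromatic carbon. Among the measured compounds shown here, no measured step covers this change, and both values at hand are limits, so there is no basis for a direction. The expectation for the step from compound 2 to compound 3 is an at least 1.1-fold lower number from compound 2 to compound 3 (0.04 log units; that floor lies within the scatter), none beyond the scatter. Compound 3 is estimated at 9000 nM, in the range 1500 nM to 40000 nM.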

Compound 3, half-maximal effective concentration: 67 nM
For compound 3 the middle estimate is 130-fold (2.13 log units) above the measured one; measured number below the stated range.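

Methylsulfanyl on an aromatic carbon, ortho to a large group and meta to a trifluoromethyl group, is the first change here to give a measurable number in this assay: the step is an at least 140-fold lower number from compound 2 to compound 3 (2.17 log units; beyond the scatter). Its full size stays open, as the value of compound 2 is a limit of the assay and not a number: the limit of > 10000 nM in this assay, at which 2 of the 3 values shown sit.

Compound 1 also carries an added group on the aromatic ring, a methoxy group, but it differs from compound 3 in more than one place, so the two groups cannot be ranked.

Still open, on these data alone, is whether this position accepts an ethylsulfanyl chain, a chlorine atom or an amine in place of methylsulfanyl. Also open, as far as these compounds go, is whether the number of compound 3 would hold with other groups elsewhere on the shared core.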